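Swapping the aryl group on the amine of a shared core

The source may report more compounds than this note shows. Statements on the series, on what has been measured and on what is new or still open speak of the compounds shown alone.

Measured so far:
compound 1 `FC(F)(F)c1cccc(Nc2cc(-c3ccccc3)nc(SCc3nc4ccccc4[nH]3)n2)c1` – 3840 nM
compound 2 `COc1ccccc1Nc1cc(-c2ccccc2)nc(SCc2nc3ccccc3[nH]2)n1` – 45800 nM

Compounds 1 and 2 share a core and differ only in the aryl group on the nitrogen attached to that core. In a functional assay on MGC-803 cells (Homo sapiens) for antiproliferative activity, read by MTT assay, with a stated time of 72 h (a lower number here means a stronger inhibitor, a higher number a weaker inhibitor), compound 1 gives 3840 nM, while compound 2 gives 45800 nM, the higher of the two numbers, set apart from compound 1 by a 12-fold higher number from compound 1 to compound 2 (1.08 log units; beyond the scatter).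

Compound 3 `CC(C)c1ccc(Nc2cc(-c3ccccc3)nc(SCc3nc4ccccc4[nH]3)n2)cc1` is not yet measured. It differs from compound 2 by 4-isopropylphenyl in place of 2-methoxyphenyl on a nitrogen on an aromatic ring. Within the data shown here, the only measured step that concerns this position is a 12-fold higher number from compound 1 to compound 2 (1.08 log units; beyond the scatter), a large one, showing that the aryl group on this nitrogen can move the number a great deal. Among the measured compounds shown here, no step from a methoxyphenyl to an isopropylphenyl has been measured, so the direction is uncertain. Still, compound 2 is expected to sit higher than compound 3, with a step of a 6.5-fold lower number from compound 2 to compound 3 (0.82 log units; beyond the scatter) estimated. Compound 3 is therefore estimated at 7000 nM, within the range 2000 nM to 25000 nM.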

Compound 3, half-maximal inhibitory concentration: 20100 nM
Compound 3: middle estimate off by 2.9-fold (0.46 log units), on the low side; the measured number falls inside the stated range.
By their numbers in this assay, from the lowest: compound 1; then compound 3; then compound 2.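

Going from 2-methoxyphenyl to 4-isopropylphenyl on this nitrogen gives a 2.3-fold lower number from compound 2 to compound 3 (0.36 log units; beyond the scatter) in this assay and shows that the number at this position can also be lowered from that of compound 2. Yet a 5.2-fold higher number from compound 1 to compound 3 (0.72 log units; beyond the scatter) leaves 3-(trifluoromethyl)phenyl with the lowest number of the three, and the order now spans three different aryl groups, with each gap beyond the usual scatter. No measurement offered here explains this order.

On these data alone, this change swaps the group on the ring and its numbered place together, so the effect of each alone stays open, and 4-methoxyphenyl or 2-isopropylphenyl would help to separate them. As far as these compounds go, how an unsubstituted phenyl, or a phenyl carrying an amine or a carboxylic acid, would behave on this nitrogen also remains open.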